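The source may hold more compounds than are shown below. What is called first, only, known or untested is meant among the compounds shown, and "the series" means these compounds.

Values in a functional assay on EBC-1 cells (Homo sapiens) for antiproliferative activity, with a stated time of 72 h (a higher number here means a weaker inhibitor, a lower number a stronger inhibitor), so far
compound 1 `Cn1cc(-c2cc(C(F)(F)F)c3ncc(Cc4ccc5ncccc5c4)n3c2)cn1` gives "not determined" (no result reported)
compound 2 `Fc1cc(-c2ccsc2)cn2c(Cc3ccc4ncccc4c3)cnc12` gives 444 nM
compound 3 `N#Cc1cccc(-c2cc(F)c3ncc(Cc4ccc5ncccc5c4)n3c2)c1` gives 107 nM

Within the data shown here, compound 3 at 107 nM holds the lower of the two actual numbers, while compound 2 at 444 nM is its only numerical neighbour. Compound 1 offers no number for comparison.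

Next in line for measurement is compound 4 `CNC(=O)c1cccc(-c2cc(F)c3ncc(Cc4ccc5ncccc5c4)n3c2)c1` which differs from compound 3 as follows: methylcarbamoyl in place of cyano on an aromatic carbon and so methylcarbamoyl stands in place of cyano on an aromatic carbon, turning 3-cyanophenyl into 3-(methylcarbamoyl)phenyl.

Among the measured compounds shown here, only one measured step bears on this change. The step of a 4.1-fold lower number from compound 2 to compound 3 (0.62 log units; beyond the scatter) is modest and lies beyond the scatter, but it exchanges thiophen-3-yl for 3-cyanophenyl as a whole. For the measured compounds named here, no measured step alters the cyano group alone, so the data give no direction for the present change. Going by the values given here, with the step of a 4.1-fold lower number from compound 2 to compound 3 (0.62 log units; beyond the scatter) as the only guide to size, a shift in this assay no larger than that modest one is expected, and most likely none beyond the scatter. The expected change is a 1.1-fold lower number from compound 3 to compound 4 (0.03 log units; within the scatter) and it is expected to stay within the scatter. The estimate for compound 4 is 100 nM with 35 nM to 300 nM as the expected range.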

Compound 4, half-maximal inhibitory concentration: 400 nM
Compound 4: the middle estimate sits 4.0-fold (0.60 log units) below what was measured; the whole stated range lies below it.
By their numbers in this assay, from the lowest: compound 3; then compounds 4 and 2 (each within the scatter of the next).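

In this assay, methylcarbamoyl in place of cyano gives a 3.7-fold higher number from compound 3 to compound 4 (0.57 log units; beyond the scatter) and so shows that this aromatic carbon of the phenyl group is sensitive to its substituent alone, which the earlier pair, with its whole-group exchange, could not show. Set against thiophen-3-yl, 3-(methylcarbamoyl)phenyl gives a 1.1-fold lower number from compound 2 to compound 4 (0.05 log units; within the scatter) and stays within the scatter, so the advantage of 3-cyanophenyl over thiophen-3-yl does not carry over to every group with a substituent at this place. No measurement on these compounds accounts for the step from nitrile to amide.

On these data alone, whether a primary amide, a carboxylic acid or an aminomethyl group on the same aromatic carbon would track with compound 3 or with compound 4 remains open, as does the separate contribution of the amide hydrogen and the added methyl. As far as these compounds go, what a change of the fluoro group on the shared core does is likewise open: compound 1, carrying trifluoromethyl, gives "not determined" (no result reported) and also differs in its other substituent.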